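Pyridinylmethylamino in Place of a Thiophene Ether

This account rests on a few compounds, and the source may have more. Where it says the series, first, only, none or still open, it means among the compounds named here.

compound 1 `O=C(COCc1ccccc1)N1CCN(c2ccc(Cl)cc2Cl)CC1`: 1000 nM
compound 2 `O=C(COCc1cccs1)N1CCN(c2ccc(Cl)cc2Cl)CC1`: > 310 nM

In a functional assay on HEK293 cells for positive allosteric modulation of metabotropic glutamate receptor 5 (Homo sapiens), read by FLIPR and calcium flux (a lower number here means that less compound is needed, a higher number that more compound is needed for the effect), compound 1 gives 1000 nM. For compound 2 the reported > 310 nM is a limit of the assay, not a number. Hence the limit of > 310 nM in this assay, at which 1 of the 2 values shown sits, leaves a step that the limit leaves unreadable from compound 1 to compound 2 unsized, and compound 2 stands only as a range in this assay. Compound 3 `O=C(CNCc1ccncc1)N1CCN(c2ccc(Cl)cc2Cl)CC1` carries the change (((pyridin-4-yl)methyl)amino in place of (thiophen-2-yl)methoxy on a saturated chain carbon bound to a carbonyl carbon). For the measured compounds named here, no measured step bears on this change, so no direction is foreseen. Compound 3 is expected to give 2000 nM in this assay, within 400 nM to 15000 nM. The step that the limit leaves unreadable from compound 2 to compound 3 is thus estimated to lie within the scatter.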

Compound 3, half-maximal effective concentration: 8500 nM
The estimate for compound 3 lay 4.3-fold (0.63 log units) below the measured number; low and high end bracket the measured number.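

In this assay, ((pyridin-4-yl)methyl)amino in place of benzyloxy on a saturated chain carbon bound to a carbonyl carbon gives an 8.5-fold higher number from compound 1 to compound 3 (0.93 log units; beyond the scatter), which shows that this place responds to a change of this kind and that, here, more compound is needed. The step from compound 2 to compound 3 cannot be read because compound 2 stands only as a limit of the assay: the limit of > 310 nM in this assay, at which 1 of the 3 values shown sits.

Compound 3 alters both the ring and the atom that links it to the chain. Which of the two carries the step stays open; a benzylamino group or a (pyridin-4-yl)methoxy group at this place would separate them.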